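One Pendant Ring Changed, Three Measured Points to Lean On

The source may hold more compounds than are shown below. What is called first, only, known or untested is meant among the compounds shown, and "the series" means these compounds.

Measured compounds:
compound 1 `COc1ccc(S(=O)(=O)N2CCc3cccc(-c4ccc(F)nc4)c32)cc1` gives 151 nM
compound 2 `COc1ccc(S(=O)(=O)N2CCc3cccc(-c4ccco4)c32)cc1` gives 79.2 nM
compound 3 `COc1ccc(S(=O)(=O)N2CCc3cccc(-c4ccc(F)cc4)c32)cc1` gives 94.6 nM

All three were tested in a functional assay on KB-VIN10 cells (Homo sapiens) for inhibition, with a stated time of 72 h; on this read-out higher numbers stand for weaker inhibition and lower numbers for stronger inhibition. Compound 1 holds the highest of the three numbers, but its gap to compound 3 is a 1.6-fold lower number from compound 1 to compound 3 (0.20 log units; within the scatter) and its gap to compound 2 is a 1.9-fold lower number from compound 1 to compound 2 (0.28 log units; within the scatter), so the three compounds cannot be told apart on this read-out. The same holds for a 1.2-fold higher number from compound 2 to compound 3 (0.08 log units; within the scatter).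

Compound 4 `COc1ccc(S(=O)(=O)N2CCc3cccc(-c4ccc(C#N)cc4)c32)cc1` has not yet been measured. Relative to compound 1 it differs in one place: 4-cyanophenyl in place of 6-fluoropyridin-3-yl on an aromatic carbon. The closest measured precedent is the exchange of the same group for 4-fluorophenyl, which gave a 1.6-fold lower number from compound 1 to compound 3 (0.20 log units; within the scatter); the exchange for furan-2-yl gave a 1.9-fold lower number from compound 1 to compound 2 (0.28 log units; within the scatter). Both swaps of the pendant ring stayed within the scatter, and a swap to 4-cyanophenyl is expected to behave the same way in this assay, with a step of a 1.5-fold lower number from compound 1 to compound 4 (0.18 log units; within the scatter) that is itself within the scatter. Compound 4 is therefore estimated at 100 nM, with a likely range from 50 nM to 220 nM.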

Compound 4, half-maximal inhibitory concentration: 29.2 nM
For compound 4 the middle estimate is 3.4-fold (0.53 log units) above the measured one; the whole stated range lies above it.
By their numbers in this assay, from the lowest: compound 4; then compounds 2, 3 and 1 (each within the scatter of the next).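

Among the compounds shown here, until this result, every exchange of the pendant ring on this aromatic carbon stayed within the scatter, so the position could have seemed indifferent to which ring it carried. In this assay, for the compounds shown here, the 4-cyanophenyl ring is the first to stand clear of the others, with a 5.2-fold lower number from compound 1 to compound 4 (0.71 log units; beyond the scatter) and a 2.7-fold lower number from compound 2 to compound 4 (0.43 log units; beyond the scatter) as the ring changes. The tightest comparison changes only the group on a phenyl ring, cyano in place of fluoro, and gives a 3.2-fold lower number from compound 3 to compound 4 (0.51 log units; beyond the scatter), so what the ring carries can matter here, though no measurement shown explains the difference.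

From the compounds shown here alone, it remains open whether other groups on the phenyl ring, such as a methoxy, an amide or a carboxylic acid, would shift the number in the same way. Also open, going by these compounds, is whether a nitrile on a pyridine or furan ring would give a similar step.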